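A few compounds are considered here, and "the series" means these few. Any claim that something is new, unique, unknown or untested is made for them only; others in the source may bear on it.

Measured compounds in a functional assay on DU-145 cells (Homo sapiens) for antiproliferative activity, read by MTT assay, with a stated time of 48 h; on this read-out lower numbers stand for stronger inhibition and higher numbers for weaker inhibition:
Compound 1 `COc1cc(O)ccc1N1CCN(CC(O)COc2ccc(O)c3ccccc23)CC1` gives > 50000 nM, which is a limit of the assay rather than a number.
Compound 2 `Oc1ccc(N2CCN(CC(O)COc3ccc(O)c4ccccc34)CC2)c(O)c1` gives 20300 nM.
Compound 3 `Oc1ccccc1N1CCN(CC(O)COc2cccc3ccccc23)CC1` gives 18000 nM.

Of the two numbers shown, compound 3 has the lower one, but its gap to compound 2 lies within the scatter, so the two cannot be told apart. Compound 4 `Oc1ccc(N2CCN(CC(O)COc3cccc4ccccc34)CC2)c(O)c1` differs from compound 3 by hydroxy in place of hydrogen on an aromatic carbon. Within the data shown here, the only measured step, an at least 2.4-fold lower number from compound 1 to compound 2 (0.39 log units; beyond the scatter), concerns a different kind of change and so says little about adding a hydroxy group. Among the measured compounds shown here, with no matching step, no change beyond the scatter is expected, and the step from compound 3 to compound 4 in this assay is estimated as no change at the digits printed from compound 3 to compound 4 (within the scatter). Compound 4 is therefore expected at about 18000 nM, likely between 8000 nM and 45000 nM.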

Compound 4, half-maximal inhibitory concentration: 11600 nM
For compound 4 the middle estimate is 1.6-fold (0.19 log units) above the measured one, within the range that was stated.
By their numbers in this assay, from the lowest: compounds 4, 3 and 2 (each within the scatter of the next). At a limit, above all of these: compound 1.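

In this assay, adding a hydroxy group para to a large group gives a 1.6-fold lower number from compound 3 to compound 4 (0.19 log units; within the scatter), so the change from 2-hydroxyphenyl to 2,4-dihydroxyphenyl cannot be told apart from no change. A second hydroxy change, on an aromatic carbon of the other ring, gives a 1.8-fold lower number from compound 2 to compound 4 (0.24 log units; within the scatter), so this step cannot be told apart from no change either. Nothing measured here bears on why these steps are so small. The compounds shown leave open whether an amine or a carboxylic acid on this same aromatic carbon would move the number beyond the scatter.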